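Same Substitution Tried Again on a Rearranged Core

The source may report more compounds than this note shows. Statements on the series, on what has been measured and on what is new or still open speak of the compounds shown alone.

In a functional assay on IMR-32 cells (Homo sapiens) for cytotoxicity, read by sulforhodamine B assay, with a stated time of 48 h (on this read-out lower numbers stand for stronger inhibition and higher numbers for weaker inhibition), three compounds have been measured: compound 1 `COc1ccc(C2CC(c3cccc4ccccc34)=NN2C(C)=O)cc1` gives 4990 nM; compound 2 `CC(=O)N1N=C(c2cccc3ccccc23)CC1/C=C/c1ccccc1` gives 26700 nM; compound 3 `COc1ccc(C2CC(c3ccc4ccccc4c3)=NN2CC=O)cc1` gives 4120 nM.

Compound 1 and compound 2 differ by 2-phenylethenyl in place of 4-methoxyphenyl on a saturated ring carbon, and this change gave a 5.4-fold higher number from compound 1 to compound 2 (0.73 log units; beyond the scatter). Compound 3 has the same atoms as compound 1 joined differently; the difference between the two cores is not broken down here. Compound 4 `O=CCN1N=C(c2ccc3ccccc3c2)CC1/C=C/c1ccccc1` has not been measured yet. It differs from compound 3 by 2-phenylethenyl in place of 4-methoxyphenyl on a saturated ring carbon. This is the same kind of change as that from compound 1 to compound 2, not the same one: in compound 1 the neighbouring ring atom bears an acetyl group, in compound 3 a formylmethyl group. Within the data shown here, since compound 3 and compound 1 give numbers within the usual scatter of each other, the earlier step, a 5.4-fold higher number from compound 1 to compound 2 (0.73 log units; beyond the scatter), is the only guide. The expected step is a 5.3-fold higher number from compound 3 to compound 4 (0.73 log units; beyond the scatter). Compound 4 is therefore estimated at 22000 nM.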

Compound 4, half-maximal inhibitory concentration: 17200 nM
Beside the measured number, compound 4's estimate is 1.3-fold (0.11 log units) above it; the measured number falls inside the stated range.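

Putting 2-phenylethenyl in place of 4-methoxyphenyl on the rearranged core gave a 4.2-fold higher number from compound 3 to compound 4 (0.62 log units; beyond the scatter) in this assay as well. Two pairs cannot show that the change would behave the same way on any other core, and they do not explain why the number rises. Still, the change carried over between these two cores, in the same direction and by a similar amount: the same change on two cores in this assay, a 5.4-fold higher number (0.73 log units; beyond the scatter) from compound 1 to compound 2 and a 4.2-fold higher number (0.62 log units; beyond the scatter) from compound 3 to compound 4, 1.3-fold (0.11 log units) apart, within the scatter of two such steps

Going by these compounds, it remains open whether the step would hold if the ring atom that bears the formylmethyl group carried an amine or a carboxylic acid instead. Also open, on these data alone, is how the change would behave in other cell lines.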